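From pyrazole to methylcarbamoyl on a fused core

The source may hold more compounds than are shown below. What is called first, only, known or untested is meant among the compounds shown, and "the series" means these compounds.

Compound 1 `c1ccc(-c2cccc3c2CCC3c2ncc[nH]2)nc1` gives in a functional assay on CHO cells for agonist activity at Alpha-1B adrenergic receptor (Homo sapiens), read by FLIPR and calcium flux (on this read-out higher numbers stand for an effect only at larger amounts of compound and lower numbers for an effect already at smaller amounts), only a limit, > 10000 nM.
Compound 2 `c1cc(-c2ccn[nH]2)c2c(c1)C(c1ncc[nH]1)CC2` gives in this assay 600 nM.
Compound 3 `Cc1oncc1-c1cccc2c1CCC2c1ncc[nH]1` gives in this assay only a limit, > 10000 nM.

For the measured compounds named here, compound 2 therefore stands alone: it carries the only number among the three, while the other two values rest at the limit of the assay (the limit of > 10000 nM in this assay, at which 2 of the 3 values shown sit). The step to compound 4 `CNC(=O)c1cccc2c1CCC2c1ncc[nH]1` changes the same aromatic carbon once more, (methylcarbamoyl in place of 1H-pyrazol-5-yl on an aromatic carbon).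

Going by the values given here, two measured steps bear on this position. Moving from pyridin-2-yl to 1H-pyrazol-5-yl gave an at least 16-fold lower number from compound 1 to compound 2 (1.22 log units; beyond the scatter), and moving on from 1H-pyrazol-5-yl to 5-methyl-1,2-oxazol-4-yl gave an at least 16-fold higher number from compound 2 to compound 3 (1.22 log units; beyond the scatter); the direct comparison of compound 1 and compound 3 is a step that the two limits leave unreadable from compound 1 to compound 3. Every group tried on this carbon other than 1H-pyrazol-5-yl has landed at the limit, and methylcarbamoyl is a third, ringless alternative. Compound 4 is thus expected to show a large step toward higher numbers in this assay, a 13-fold higher number from compound 2 to compound 4 (1.12 log units; beyond the scatter), with a fair chance that only a limit will be reported. The estimate for compound 4 is 8000 nM, expected to fall between 2000 nM and 30000 nM.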

Compound 4, half-maximal effective concentration: > 10000 nM
Compound 4: a limit, no number; the forecaster's own chance of this, stated with the estimate: 55%; middle value at least 1.2-fold (0.09 log units) away from the limit.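

In this assay, methylcarbamoyl in place of 1H-pyrazol-5-yl gives an at least 16-fold higher number from compound 2 to compound 4 (1.22 log units; beyond the scatter), although both groups carry 1 hydrogen-bond donor and 1 hydrogen-bond acceptor, so matching those two counts was not enough to keep the readable value of compound 2 on this aromatic carbon. For the compounds shown here, the earlier replacements of 1H-pyrazol-5-yl were ring groups, whereas methylcarbamoyl has no ring, so the absence of a readable value at this position now extends to a ringless group, and 1H-pyrazol-5-yl remains the only group here with a number. Compound 4 gives only a limit, and the steps among compound 1, compound 3 and compound 4 cannot be read, with all three at the same limit: the limit of > 10000 nM in this assay, at which 3 of the 4 values shown sit.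

These limits leave open how far compound 1, compound 3 and compound 4 lie from one another, so no order can be given among pyridin-2-yl, 5-methyl-1,2-oxazol-4-yl and methylcarbamoyl. From the compounds shown here alone, what sets 1H-pyrazol-5-yl apart also stays open: 1H-imidazol-2-yl, a carbamoyl group without the methyl or a carboxylic acid on the same carbon would bear on that question.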